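The source may report more compounds than this note shows. Statements on the series, on what has been measured and on what is new or still open speak of the compounds shown alone.

Working notes on the series. Compound 1 `CNc1nc(-c2ccccc2)nc2c1nnn2Cc1ccccc1` gives 353 nM in an assay on Cerebral cortex for displacement of a labelled ligand from adenosine receptor A1 (Bos taurus); a higher number here means a weaker inhibitor, a lower number a stronger inhibitor. Among the compounds with values here, compound 2 `CCNc1nc(-c2ccccc2)nc2c1nnn2Cc1ccccc1` gives 91 nM in this assay, and the step of a 3.9-fold lower number from compound 1 to compound 2 (0.59 log units; beyond the scatter) is the only single-point change with a number on both sides. Compound 3 `CCNc1nc(-c2ccccc2)nc2c1nnn2Cc1ccccc1C(F)(F)F`, which adds a trifluoromethyl group, gives "not determined" (no result reported) in this assay, so it contributes nothing to the comparison. On the numbers shown, compound 2 stands lowest of the two; its nearest neighbour is compound 1, separated by the step of a 3.9-fold lower number from compound 1 to compound 2 (0.59 log units; beyond the scatter).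

Compound 4 `CCCNc1nc(-c2ccccc2)nc2c1nnn2Cc1ccccc1` is not yet measured. It differs from compound 2 by methyl in place of hydrogen on a saturated chain carbon, two bonds along the chain from a nitrogen on an aromatic ring. Within the data shown here, the one measured step that bears on this is a 3.9-fold lower number from compound 1 to compound 2 (0.59 log units; beyond the scatter), which is the same kind of change one bond closer to the nitrogen on the aromatic ring and gave a modest gain. A second lengthening of the chain is expected to give at most a smaller gain, and possibly none beyond the scatter, since no second homologation has been measured in this set. The estimated step of a 1.5-fold lower number from compound 2 to compound 4 (0.18 log units; within the scatter) is therefore expected to be small. For compound 4 the expected value in this assay is 60 nM, with a range of 25 nM to 150 nM.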

Compound 4, inhibition constant: 37 nM
Compound 4: middle estimate off by 1.6-fold (0.21 log units), on the high side; low and high end bracket the measured number.
By their numbers in this assay, from the lowest: compound 4; then compound 2; then compound 1.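

The ethylamino to propylamino change at this position still lowers the number in this assay, with a 2.5-fold lower number from compound 2 to compound 4 (0.39 log units; beyond the scatter) as the step, so the effect of chain length does not end at ethylamino. Over the whole change from methylamino to propylamino the result is a 9.5-fold lower number from compound 1 to compound 4 (0.98 log units; beyond the scatter) and, among the three compounds with a number, each added methyl on this chain gives a step beyond the scatter in the same direction, with none going against it. Nothing available bears on the reason for this trend.

The compounds shown do not say whether a butyl group or a longer chain on the same nitrogen would lower the number further, or where the trend would level off or turn back. They also leave open whether the length of the chain alone matters, since a branched group such as isopropyl or a ring such as cyclopentyl on this nitrogen does not appear among them.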